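The compounds below may be only part of what the source reports. "The series", "measured", "known", "first", "only" and "open" are said of these compounds alone.

Measured compounds in a functional assay on A549 cells (Homo sapiens) for cytotoxicity, read by MTT assay, with a stated time of 72 h; on this read-out lower numbers stand for stronger inhibition and higher numbers for weaker inhibition:
compound 1 `CN(C)CCn1cnnc1-c1cc(Oc2ccc(NC(=O)N/N=C/c3c(O)ccc4ccccc34)cc2F)ccn1` gives 880 nM
compound 2 `CN(C)CCn1cnnc1-c1cc(Oc2ccc(NC(=O)N/N=C/c3ccccc3O[N+](=O)[O-])cc2F)ccn1` gives 1200 nM

Compound 2 stands with the highest of the two numbers in this assay; the nearest is compound 1, and the step of a 1.4-fold higher number from compound 1 to compound 2 (0.13 log units; within the scatter) is within the scatter, so the two values show no order between them.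

Compound 3 `COc1ccc(/C=N/NC(=O)Nc2ccc(Oc3ccnc(-c4nncn4CCN(C)C)c3)c(F)c2)cc1O` is the next member of the series. Its change against compound 2 is 3-hydroxy-4-methoxyphenyl in place of 2-(nitrooxy)phenyl on a carbon with a double bond to nitrogen.

Among the measured compounds shown here, the only measured step at this position of the shared core is a 1.4-fold higher number from compound 1 to compound 2 (0.13 log units; within the scatter), an exchange of the aryl group on the carbon with a double bond to nitrogen that produced nothing beyond the scatter. On that basis the step to compound 3 is expected to be small, a 1.2-fold lower number from compound 2 to compound 3 (0.08 log units; within the scatter), with no direction claimed beyond the scatter.

The value of compound 3 in this assay is therefore estimated at 1000 nM, with a range from 400 nM to 2500 nM.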

Compound 3, half-maximal inhibitory concentration: > 100000 nM
Compound 3: only a limit was reported (the forecaster's own chance of this, stated with the estimate: 5%); middle value at least 100-fold (2.00 log units) away from the limit.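

The aryl group on the carbon with a double bond to nitrogen is not a silent place on the shared core in this assay, as an at least 83-fold higher number from compound 2 to compound 3 (1.92 log units; beyond the scatter) and an at least 110-fold higher number from compound 1 to compound 3 (2.05 log units; beyond the scatter). Compound 3 has no exact value here, only a limit, so both steps are minimum sizes: the limit of > 100000 nM in this assay, at which 1 of the 3 values shown sits. The 2-hydroxynaphthalen-1-yl and 2-(nitrooxy)phenyl groups gave values within the scatter of each other, so only the entry of 3-hydroxy-4-methoxyphenyl shows that this place can separate the compounds sharply.

The compounds shown do not tell whether the hydroxy group, the methoxy group or their combination accounts for the step. On these data alone, how a plain phenyl, a 3-hydroxyphenyl or a 4-methoxyphenyl group would read at this place remains open.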